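A few compounds are considered here, and "the series" means these few. Any claim that something is new, unique, unknown or untested is made for them only; others in the source may bear on it.

Compound 1 `CCOC(=O)c1sc2cc(Oc3ccnc(C(=O)NC)c3)ccc2c1N`: 110 nM
Compound 2 `CNC(=O)c1cc(Oc2ccc3cc(C(=O)OC(C)C)n(C)c3c2)ccn1`: 10300 nM

In an ADME assay on H1-HeLa cells (Homo sapiens) for cytotoxicity, read by MTT assay, with a stated time of 3 days (on this read-out higher numbers stand for lower toxicity in this test and lower numbers for higher toxicity in this test), compound 2 stands highest of the two numbers at 10300 nM, and its gap to compound 1 lies beyond the scatter. Compound 3 `CNC(=O)c1cc(Oc2ccc3c(C)c(C(=O)OC(C)C)n(C)c3c2)ccn1` differs from compound 2 by methyl in place of hydrogen on an aromatic carbon, with methyl in place of hydrogen on an aromatic carbon, next to the ring atom that bears an isopropoxycarbonyl group. Among the compounds with values here, no measured pair shows a change of this kind, so no step beyond the scatter is expected in this assay. The estimated change is a 1.3-fold lower number from compound 2 to compound 3 (0.11 log units; within the scatter). For compound 3 the expected value is 8000 nM, within an estimated range of 2500 nM to 25000 nM.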

Compound 3, half-maximal cytotoxic concentration: 11200 nM
Compound 3: the middle estimate sits 1.4-fold (0.15 log units) below what was measured, and the stated range covers the measured number.
By their numbers in this assay, from the lowest: compound 1; then compounds 2 and 3 (each within the scatter of the next).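

In this assay methyl in place of hydrogen on the aromatic carbon next to the ring atom that bears an isopropoxycarbonyl group gives a 1.1-fold higher number from compound 2 to compound 3 (0.04 log units; within the scatter) and thus no step beyond the scatter. This is the first single-place change among the compounds shown, and it indicates that this carbon accepts a methyl group with no measurable effect on this read-out. Nothing at hand offers an explanation for this result. On these data alone, whether an amine or a longer chain on this carbon would leave the number within the scatter remains open. So does whether methyl here would behave alike with a carboxylic acid in place of the isopropoxycarbonyl group.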